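The source may report more compounds than this note shows. Statements on the series, on what has been measured and on what is new or still open speak of the compounds shown alone.

Measured compounds:

Compound 1, `Cc1ccc(NC(=O)Nc2ccccc2F)cc1NC(=O)c1cnoc1C`: in a functional assay on U-937 cells (Homo sapiens) for antiproliferative activity, read by MTT assay, with a stated time of 24 h (on this read-out higher numbers stand for weaker inhibition of growth and lower numbers for stronger inhibition of growth), compound 1 gives > 30000 nM, which is a limit of the assay and not a number.
Compound 2, `Cc1ccc(NC(=O)Nc2ccc(Cl)c(Cl)c2)cc1NC(=O)c1cnoc1C`: compound 2 gives 1890 nM.
Compound 3, `Cc1cc(NC(=O)Nc2ccccc2F)ccc1NC(=O)c1cnoc1C`: compound 3 gives > 30000 nM, again a limit of the assay.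
Not yet measured: compound 4, `Cc1cc(NC(=O)Nc2ccc(Cl)c(Cl)c2)ccc1NC(=O)c1cnoc1C`.

Going by the values given here, the one change that has been followed with numbers is 3,4-dichlorophenyl in place of 2-fluorophenyl on an amide-type nitrogen. It gave an at least 15-fold lower number from compound 1 to compound 2 (1.20 log units; beyond the scatter). The size of that step is only a lower bound because of the limit of > 30000 nM in this assay, at which 2 of the 3 values shown sit.

The same change is now to be read on the core of compound 3: 3,4-dichlorophenyl in place of 2-fluorophenyl on an amide-type nitrogen. The place lines of both changes are the same word for word, so this is the same change on a different core. The difference between the core of compound 1 and the core of compound 3 is not broken down here; the two share the same atoms joined differently, and compound 3 sits at the limit as compound 1 does.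

For compound 4, the expectation is a step in the same direction, and it is expected to read an at least 7.5-fold lower number from compound 3 to compound 4 (0.87 log units; beyond the scatter), resting on the measured step of an at least 15-fold lower number from compound 1 to compound 2 (1.20 log units; beyond the scatter). Since the starting point for compound 3 is only a limit, the size of the expected step cannot be tied down more closely. Compound 4 is expected to land at about 4000 nM in this assay, most likely between 1200 nM and 20000 nM.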

Compound 4, concentration for 50% growth inhibition: > 30000 nM
Compound 4 ended at the assay's limit; the forecaster's own chance of this, stated with the estimate: 30%; middle value at least 7.5-fold (0.87 log units) away from the limit.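

No step from compound 3 to compound 4 can be read, because the values of both compounds are limits of the assay and not numbers: the limit of > 30000 nM in this assay, at which 3 of the 4 values shown sit.

The compounds shown leave open whether 3,4-dichlorophenyl in place of 2-fluorophenyl on an amide-type nitrogen changes growth inhibition at all on the core of compound 3, as it does on the core of compound 1.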